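Shifting the Phenyl Around the Pyrrolidine Ring

A few compounds are considered here, and "the series" means these few. Any claim that something is new, unique, unknown or untested is made for them only; others in the source may bear on it.

Compound 1 `CCCN(CCC(F)(F)F)Cc1c(C(F)(F)F)nc2n(-c3c(C)cc(C)cc3C)c(Cl)cn12` gives 12 nM in an assay on cells for displacement of a labelled ligand from corticotropin-releasing factor receptor 1 (Homo sapiens), with a stated time of 100 min; a lower number here means a stronger inhibitor, a higher number a weaker inhibitor.
Compound 2 `Cc1cc(C)c(-n2c(Cl)cn3c(CN(C)Cc4ccco4)c(C(F)(F)F)nc23)c(C)c1` gives 180 nM in this assay.
Compound 3 `Cc1cc(C)c(-n2c(Cl)cn3c(CN4CCCC4c4ccccc4)c(C(F)(F)F)nc23)c(C)c1` gives > 7000 nM in this assay.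

Compound 3 stands at the weak end of the three: its result in this assay is a limit of the assay and not a number (the limit of > 7000 nM in this assay, at which 1 of the 3 values shown sits). The steps leading to it are both large, an at least 580-fold higher number from compound 1 to compound 3 (2.76 log units; beyond the scatter) and an at least 38-fold higher number from compound 2 to compound 3 (1.58 log units; beyond the scatter), while the step of a 15-fold higher number from compound 1 to compound 2 (1.18 log units; beyond the scatter) is also beyond the scatter.

Compound 4 `Cc1cc(C)c(-n2c(Cl)cn3c(CN4CCC(c5ccccc5)C4)c(C(F)(F)F)nc23)c(C)c1` differs from compound 3 only in the amine: 3-phenylpyrrolidin-1-yl in place of 2-phenylpyrrolidin-1-yl on a saturated chain carbon bound to an aromatic carbon. Among the compounds with values here, no measured step changes the position of a substituent within an amine ring; the measured steps only show that swapping the whole amine moves the numbers in this assay by large amounts. Compound 4 is therefore expected to give about 3000 nM in this assay, within 400 nM to 20000 nM. The estimated step of an at least 2.3-fold lower number from compound 3 to compound 4 (0.36 log units; beyond the scatter) is thus toward a lower number, but with wide uncertainty, and a limit may again be reported.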

Compound 4, inhibition constant: 610 nM
Beside the measured number, compound 4's estimate is 4.9-fold (0.69 log units) above it; low and high end bracket the measured number.
By their numbers in this assay, from the lowest: compound 1; then compound 2; then compound 4. At a limit, above all of these: compound 3.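

With the same atoms joined differently, 3-phenylpyrrolidin-1-yl in place of 2-phenylpyrrolidin-1-yl gives an at least 11-fold lower number from compound 3 to compound 4 (1.05 log units; beyond the scatter) in this assay, so the place of the phenyl on the ring matters and not only the choice of the whole amine. From the compounds shown here alone, the result for compound 3 is a limit of the assay and not a number, so the true size of this step remains unknown: the limit of > 7000 nM in this assay, at which 1 of the 4 values shown sits. Even so, the 3-phenylpyrrolidin-1-yl group does not match the two earlier amines, with a 3.4-fold higher number from compound 2 to compound 4 (0.53 log units; beyond the scatter) and a 51-fold higher number from compound 1 to compound 4 (1.71 log units; beyond the scatter).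

The compounds shown leave open how a plain pyrrolidine without the phenyl would compare, so it cannot be said whether the phenyl on the ring lowers or raises the number. They also leave open how a 4-phenylpiperidine would fare.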